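The compounds below may be only part of what the source reports. "The series", "measured", "known", "first", "only" and "open" are said of these compounds alone.

Measured in a functional assay on MCF7 cells (Homo sapiens) for inhibition, read by fluorescence, with a stated time of 72 h; a higher number here means a weaker inhibitor of growth, a lower number a stronger inhibitor of growth:
- compound 1 `CCCCn1cnc2c(Nc3ccc(Cl)cc3)nc(N[C@H]3CC[C@H](N)CC3)nc21`: 2100 nM
- compound 2 `CC(C)CCn1cnc2c(Nc3ccccc3)nc(N[C@H]3CC[C@H](N)CC3)nc21`: 5400 nM
- compound 3 `CCCCn1cnc2c(Nc3cccc(Cl)c3)nc(N[C@H]3CC[C@H](N)CC3)nc21`: 2000 nM

Going from 4-chlorophenyl to 3-chlorophenyl gives a 1.1-fold lower number from compound 1 to compound 3 (0.02 log units; within the scatter), so compound 3 stands level with compound 1. Compound 2 reads a higher number than compound 3, and that gap lies beyond the scatter.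

The next compound to be tested in this assay is compound 4 `CCCCn1cnc2c(Nc3ccccc3)nc(N[C@H]3CC[C@H](N)CC3)nc21`. It is compound 3 without its chlorine, with hydrogen in place of chloro on an aromatic carbon. The 3-chlorophenyl thus becomes phenyl.

Going by the values given here, no measured step removes a chloro group directly. Among the compounds with values here, the only step available, a 1.1-fold lower number from compound 1 to compound 3 (0.02 log units; within the scatter), moves that group around the ring and so says little about losing it. The nearest hint comes from a compound with the same phenyl as compound 4 but a different chain: compound 2 reads 5400 nM. That comparison is confounded by the chain, so it supports only a modest expectation: a small step towards a higher number, possibly no larger than the scatter.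

The expected move is a 1.7-fold higher number from compound 3 to compound 4 (0.22 log units; within the scatter). Compound 4 is estimated at 3300 nM, with an expected range of 1700 nM to 6500 nM.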

Compound 4, concentration for 50% growth inhibition: 2200 nM
Estimate against measurement, compound 4: 1.5-fold (0.18 log units) above; the measured number falls inside the stated range.
By their numbers in this assay, from the lowest: compounds 3, 1 and 4 (each within the scatter of the next); then compound 2.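

In this assay, taking the chloro group off the 3-chlorophenyl gives a 1.1-fold higher number from compound 3 to compound 4 (0.04 log units; within the scatter) and taking it off the 4-chlorophenyl gives a 1.0-fold higher number from compound 1 to compound 4 (0.02 log units; within the scatter) and so neither loss separates the compounds. Going by these compounds alone, the earlier compounds showed only that the chlorine could change place on the aromatic ring without a reading beyond the scatter, whereas these steps show that the plain phenyl also stands level with both chlorinated compounds. Within the data shown here, the result also gives the first comparison of the chain alone, where hydrogen in place of methyl on a saturated chain carbon gives a 2.5-fold lower number from compound 2 to compound 4 (0.39 log units; beyond the scatter) and this is the only new step that lies beyond the scatter.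

The compounds leave open whether a group other than chloro on the phenyl, such as methoxy, nitrile or a carboxylic acid, would move the number in this assay at all. Among these compounds, they also leave open how a longer chain or a chain carrying an amine would read, with a single pair of compounds so far bearing on the chain. Nothing available here offers an explanation for either the flat response at the ring or the step at the chain.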